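Swapping One Ring Among Three Closely Matched Compounds

The source may report more compounds than this note shows. Statements on the series, on what has been measured and on what is new or still open speak of the compounds shown alone.

In an ADME assay on PBMC cells (Homo sapiens) for cytotoxicity (a lower number here means that less compound is tolerated, a higher number that more compound is tolerated), compound 1 (`CC(CCNC(=O)c1c(Cl)cncc1Cl)N1CCC(C(Oc2ccncc2)c2ccc(Br)cc2)CC1`) gives 31200 nM, compound 2 (`Cc1ccnc(OC(c2ccc(C(F)(F)F)cc2)C2CCN(C(C)CCNC(=O)c3c(Cl)cncc3Cl)CC2)c1`) gives 33600 nM and compound 3 (`CCO/N=C(/c1ccc(Br)cc1)C1CCN(C(C)(C)CCNC(=O)c2c(Cl)cncc2Cl)CC1`) gives 34000 nM. Compound 2 therefore stands level with the other two, as all three numbers lie within the usual scatter of one another.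

Compound 4 (`CC(CCNC(=O)c1c(Cl)cncc1Cl)N1CCC(C(Oc2cccc(Cl)c2)c2ccc(C(F)(F)F)cc2)CC1`) differs from compound 2 in one place: 3-chlorophenyl in place of 4-methylpyridin-2-yl on an oxygen on a saturated carbon. In words, 3-chlorophenyl stands in place of 4-methylpyridin-2-yl on an oxygen on a saturated carbon.

Within the data shown here, no two measured compounds differ in only one place, so no measured step shows what such a swap does in this assay. Among the measured compounds shown here, the only guide is that compound 1 at 31200 nM and compound 3 at 34000 nM remain within the scatter of each other despite their different structures. The expected change, a 1.2-fold lower number from compound 2 to compound 4 (0.06 log units; within the scatter), is small, slightly downward and within the scatter. Compound 4 is estimated at 29000 nM, with an expected range of 15000 nM to 50000 nM.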

Compound 4, half-maximal cytotoxic concentration: 8100 nM
Compound 4: the middle estimate sits 3.6-fold (0.55 log units) above what was measured, outside the stated range (below it).
By their numbers in this assay, from the lowest: compound 4; then compounds 1, 2 and 3 (each within the scatter of the next).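

In this assay, among these compounds, the swap of 4-methylpyridin-2-yl for 3-chlorophenyl gives a 4.1-fold lower number from compound 2 to compound 4 (0.62 log units; beyond the scatter) and so provides the first single-place comparison in this set. It shows that the group on this oxygen on a saturated carbon can change how much compound the cells tolerate, something the three earlier compounds could not show, as they differ from one another in more than one place. Nothing measured here explains the change.

This one swap removes a ring nitrogen and a methyl group and adds a chlorine, so the compounds shown cannot separate the contributions of these parts. A plain phenyl or a 3-methoxyphenyl group at the same place would be needed to show whether the lower number follows the chlorine, the loss of the ring nitrogen or both.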